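Replacing the Oxazole Arm with a Pyridine Arm

A few compounds are considered here, and "the series" means these few. Any claim that something is new, unique, unknown or untested is made for them only; others in the source may bear on it.

Compound 1 `O=C1[C@@H](NS(=O)(=O)c2cc3ccc(Cl)nc3s2)CCN1Cc1cc2cc[nH]cc-2n1`: 50%
Compound 2 `O=C1[C@@H](NS(=O)(=O)c2ccc(-c3ccon3)s2)CCN1Cc1cc2cc[nH]cc-2n1`: 49%
Compound 3 `CC(C)(C)c1ccc(S(=O)(=O)N[C@H]2CCN(Cc3cc4cc[nH]cc-4n3)C2=O)cc1`: 57%

Three compounds share one core and differ only in the group carried on the sulfonyl sulfur. In an assay on isolated protein for inhibition of coagulation factor X (Oryctolagus cuniculus), tested at 1 uM (on this read-out lower numbers stand for less inhibition and higher numbers for more inhibition at the one concentration tested (going by the name of the read-out)), compound 2 gives 49%, and its two neighbours sit within the scatter of it: a number 1 percentage points lower from compound 1 to compound 2 (within the scatter) and a number 8 percentage points higher from compound 2 to compound 3 (within the scatter). Likewise a number 7 percentage points higher from compound 1 to compound 3 (within the scatter). So far, exchanging one group for another of the same size at this position has not moved the read-out beyond the scatter.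

Compound 4 `O=C1[C@@H](NS(=O)(=O)c2ccc(-c3ccncc3)s2)CCN1Cc1cc2cc[nH]cc-2n1` keeps the core and the thiophene of compound 2 and changes only the outer ring: pyridin-4-yl in place of 1,2-oxazol-3-yl on an aromatic carbon. This is a smaller change than any of the three measured steps, all of which swapped the whole sulfonyl group and still stayed within the scatter. The expectation for compound 4 is therefore no step beyond the scatter, a number 1 percentage points higher from compound 2 to compound 4 (within the scatter). Compound 4 is estimated at 50%, with a range from 36% to 64%.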

Compound 4, a percentage reported as inhibition, at one concentration (the size of the read-out at that concentration, not a potency): 50%
For compound 4 middle estimate and measured number coincide at the digits printed, within the range that was stated.
By their numbers in this assay, from the lowest: compounds 2, 1, 4 and 3 (each within the scatter of the next).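

In this assay, exchanging 1,2-oxazol-3-yl for pyridin-4-yl gives a number 1 percentage points higher from compound 2 to compound 4 (within the scatter). The earlier steps shown here replaced the whole group on the sulfonyl sulfur, whereas this one changes only the outer ring, on an aromatic carbon of a five-membered aromatic ring with 1 sulfur. It shows that a six-membered aromatic ring with 1 hetero atom and a five-membered aromatic ring with 2 hetero atoms read alike at this place, and no measurement at hand explains this result.

As far as these compounds go, compounds 2 and 4 both carry an aromatic ring here, so it remains open whether a carboxylic acid or a saturated amine such as piperidin-4-yl would move the number beyond the scatter. With a single test concentration, any difference in potency among these compounds also remains open.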